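Adding a Second Hydroxy Group to Compound 1

The source may report more compounds than this note shows. Statements on the series, on what has been measured and on what is new or still open speak of the compounds shown alone.

- compound 1 `Oc1ccccc1CNc1ncnc2c1ncn2C1CCCCO1` gives > 100000 nM (a limit)
- compound 2 `COc1cccc(OC)c1CNc1ncnc2c1ncn2C1CCCCO1` gives 10300 nM
- compound 3 `COc1ccc(CNc2ncnc3c2ncn3C2CCCCO2)cc1OC` gives > 100000 nM (a limit)

In an ADME assay on K562 cells (Homo sapiens) for cytotoxicity, with a stated time of 72 h (on this read-out lower numbers stand for stronger inhibition and higher numbers for weaker inhibition), compound 1 stands at > 100000 nM as a limit of the assay, not a number. Compound 4 `Oc1cccc(CNc2ncnc3c2ncn3C2CCCCO2)c1O` turns 2-hydroxyphenyl into 2,3-dihydroxyphenyl, with hydroxy in place of hydrogen on an aromatic carbon. Changes on this ring give no single direction so far. Compound 2 gives 10300 nM as a true number. Compound 3 stays at the limit. The expected at least 2.0-fold lower number from compound 1 to compound 4 (0.30 log units; that floor lies within the scatter) is therefore modest and toward stronger inhibition, and the read-out may well remain at the limit. Compound 4 is estimated at 50000 nM (range 10000 nM to 100000 nM).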

Compound 4, half-maximal inhibitory concentration: 92000 nM
Compound 4: the middle estimate sits 1.8-fold (0.26 log units) below what was measured; the range from low to high includes it.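

In this assay, among these compounds, compound 4 gives a true number and no longer a limit, so the first hydroxy group on this ring can be joined by a second without leaving the read-out out of reach. The step itself is only an at least 1.0-fold lower number from compound 1 to compound 4 (0.03 log units; that floor lies within the scatter). How large the real step is cannot be read, because compound 1 is only a limit: the limit of > 100000 nM in this assay, at which 2 of the 4 values shown sit.

As far as these compounds go, whether an amine or a chlorine atom on this same aromatic carbon would give a lower number stays open. So does whether the hydroxy group would have the same effect on compound 2.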